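The source may hold more compounds than are shown below. What is called first, only, known or untested is meant among the compounds shown, and "the series" means these compounds.

Measured so far in an ADME assay on MCF-10A cells (Homo sapiens) for cytotoxicity, read by MTT assay, with a stated time of 24 h; on this read-out lower numbers stand for stronger inhibition and higher numbers for weaker inhibition:
- compound 1 `FC(F)(F)C(F)(F)C(F)(F)C(F)(F)C(F)(F)C(F)(F)CCn1cc(COc2ccccc2-c2nc3ccccc3s2)nn1` gives 35100 nM
- compound 2 `FC(F)(F)Oc1ccc(-c2cc(COc3ccccc3-c3nc4ccccc4s3)on2)cc1` gives 43900 nM
- compound 3 `Fc1ccc(-n2cc(COc3ccccc3-c3nc4ccccc4s3)nn2)cc1` gives 33300 nM

All three numbers sit close together. Compound 3 is not separated beyond the usual scatter from compound 1, and its gap to compound 2 also stays within that scatter, so on these numbers compound 3 stands level with the other two rather than apart from them.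

Compound 4 `c1ccc(-n2cc(COc3ccccc3-c3nc4ccccc4s3)nn2)cc1` is the next member and has not yet been run in this assay. It differs from compound 3 only at the outer ring: hydrogen in place of fluoro on an aromatic carbon. No step between two measured compounds that differ in exactly one place is available, so there is no measured precedent for a change of this kind in this series.

Given that the three measured compounds, which differ from one another in larger portions of the molecule, all return numbers within the scatter of each other, the expectation for this smaller change is no step beyond the scatter, in either direction: the step expected is a 1.1-fold higher number from compound 3 to compound 4 (0.03 log units; within the scatter). Compound 4 is therefore estimated at 36000 nM in this assay, with a range from 18000 nM to 72000 nM.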

Compound 4, half-maximal inhibitory concentration: 36400 nM
The estimate for compound 4 lay 1.0-fold (0.00 log units) below the measured number, within the range that was stated.
By their numbers in this assay, from the lowest: compounds 3, 1, 4 and 2 (each within the scatter of the next).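

In this assay, within the data shown here, the change from 4-fluorophenyl to phenyl supplies the first step between two compounds that differ in one place: a 1.1-fold higher number from compound 3 to compound 4 (0.04 log units; within the scatter) and so within the scatter. On this aromatic carbon, para to a large group, fluoro and hydrogen cannot be told apart in this read-out, so the fluoro group is not required for the number seen with compound 3. No measurement at hand bears on why these two compounds stand level.

An amine, a carboxylic acid or a methoxy group on that same carbon would show whether the position accepts anything beyond fluoro and hydrogen. Going by these compounds, with a single pair speaking to this position, it also stays open whether the same exchange gives a step within the scatter on other members.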